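Propoxy to isopropoxy: working notes on the series

A few compounds are considered here, and "the series" means these few. Any claim that something is new, unique, unknown or untested is made for them only; others in the source may bear on it.

Measured in a functional assay on the whole organism with Rattus norvegicus as the target; on this read-out higher numbers stand for an effect only at larger amounts of compound and lower numbers for an effect already at smaller amounts:
compound 1 `CCOc1ccccc1-c1ncc(-c2nn[nH]n2)c(O)n1`: 0.02 mg/kg
compound 2 `CCCOc1ccccc1-c1ncc(-c2nn[nH]n2)c(O)n1`: 0.004 mg/kg

Within the data shown here, of the two numbers so far, compound 2 has the lower, 0.004 mg/kg. The next structure, compound 3 `CC(C)Oc1ccccc1-c1ncc(-c2nn[nH]n2)c(O)n1`, has not yet been measured. Its difference from compound 2 is isopropyl in place of propyl on an oxygen on an aromatic ring; cut one bond further out, this reads propoxy to isopropoxy.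

Among the measured compounds shown here, only one measured step bears on this change: a 5.0-fold lower number from compound 1 to compound 2 (0.70 log units; beyond the scatter). There, a methyl takes the place of a hydrogen on a saturated chain carbon, so the evidence is indirect. For the measured compounds named here, no measured compound carries isopropyl on that oxygen. If the carbon count alone mattered, no step beyond the scatter would be expected, since propyl and isopropyl both hold three carbons. If the gain at compound 2 depends on the propyl chain itself, part of it should be lost. A modest rise in the number is therefore expected in this assay, without reaching far past compound 1 at 0.02 mg/kg. The expected move is a 2.5-fold higher number from compound 2 to compound 3 (0.40 log units; beyond the scatter). For compound 3 the estimate is 0.01 mg/kg, with an expected range from 0.003 mg/kg to 0.04 mg/kg.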

Compound 3, dose for 50% inhibition: 0.02 mg/kg
The estimate for compound 3 lay 2.0-fold (0.30 log units) below the measured number, within the range that was stated.
By their numbers in this assay, from the lowest: compound 2; then compounds 1 and 3 (each within the scatter of the next).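

Working in this assay, isopropyl in place of propyl on the oxygen gives a 5.0-fold higher number from compound 2 to compound 3 (0.70 log units; beyond the scatter) and so shows that the number at this position is not set by the carbon count alone, as the two groups hold the same atoms joined differently. Set against the shorter chain, a methyl on the saturated chain carbon bound to the oxygen gives no change at the digits printed from compound 1 to compound 3 (within the scatter) while the methyl of a 5.0-fold lower number from compound 1 to compound 2 (0.70 log units; beyond the scatter) is the only one of these two additions with a step beyond the scatter, so across these three compounds the place of the added methyl on the chain decides the outcome in this assay and its mere presence does not. Nothing measured on these compounds speaks to why the propyl and isopropyl chains part in this way.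

The compounds shown leave open whether a longer chain such as butyl on the same oxygen would extend the step seen with propyl or reverse it. They also leave open whether a ring on that oxygen, such as cyclopropylmethyl or cyclobutyl, would behave like propyl or like isopropyl.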